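This account rests on a few compounds, and the source may have more. Where it says the series, first, only, none or still open, it means among the compounds named here.

Of the compounds shown here, three have been measured in an assay on CHO cells for displacement of a labelled ligand from 5-hydroxytryptamine receptor 7 (Homo sapiens); on this read-out lower numbers stand for stronger inhibition and higher numbers for weaker inhibition. Compound 1 `CCC1(CCCCN2CCN(c3ccc(F)cc3)CC2)C(=O)Nc2ccc(F)cc21` gives 1.5 nM, compound 2 `CCC1(CCCCN2CCc3sccc3C2)C(=O)Nc2ccccc21` gives 4.31 nM, and compound 3 `O=C1Nc2ccc(F)cc2C1CCCCN1CCN(c2cccc(Cl)c2)CC1` gives 1.96 nM. On these three numbers compound 3 stands second highest: its nearest neighbour is compound 1, whose number is lower by an amount that falls within the scatter of repeated measurements, while compound 2 sits furthest away, with a higher number by a margin that lies beyond the scatter.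

Compound 4 `O=C1Nc2ccc(F)cc2C1CCCCN1CCN(c2ccc(F)cc2)CC1` has not yet been measured. It differs from compound 3 in a single place: 4-fluorophenyl in place of 3-chlorophenyl on an amine nitrogen in a ring. The rest of the shared core, including the fluorine on the fused aromatic ring and the four-carbon chain to the ring nitrogen, is unchanged.

For the measured compounds named here, no step between two measured compounds isolates this change, so the expectation rests on the spread seen so far. Compound 1 carries the same 4-fluorophenyl group on the ring nitrogen and, with 1.5 nM, lies within the scatter of compound 3. The step from compound 3 to compound 4 is therefore expected to be small, a 1.1-fold lower number from compound 3 to compound 4 (0.04 log units; within the scatter), with no direction beyond the scatter. Compound 4 is estimated at 1.8 nM, within a range from 0.8 nM to 4 nM.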

Compound 4, inhibition constant: 3.4 nM
Compound 4: middle estimate off by 1.9-fold (0.28 log units), on the low side, within the range that was stated.
By their numbers in this assay, from the lowest: compounds 1, 3, 4 and 2 (each within the scatter of the next, the first and the last beyond it).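

In this assay, 4-fluorophenyl in place of 3-chlorophenyl on the amine nitrogen in the ring gives a 1.7-fold higher number from compound 3 to compound 4 (0.24 log units; within the scatter), so with this shared core the measurement does not separate the two groups, which differ in both their halogen and its place on the ring. For the compounds shown here, compound 4 also provides the first reading of a second place: with 4-fluorophenyl held constant, hydrogen in place of ethyl on the saturated ring carbon gives a 2.3-fold higher number from compound 1 to compound 4 (0.36 log units; beyond the scatter), a modest step but one that lies beyond the scatter, whereas the aryl exchange does not. Nothing available explains either step.

The compounds shown leave open whether the step from ethyl to hydrogen would recur with 3-chlorophenyl on the amine nitrogen, and how a methyl or propyl group on that saturated ring carbon would read. They also leave open whether an unsubstituted phenyl or a pyridine ring on the amine nitrogen would stay within the scatter of these two aryl groups.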